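A few compounds are considered here, and "the series" means these few. Any claim that something is new, unique, unknown or untested is made for them only; others in the source may bear on it.

Compound 1, `CC(C)C(=O)Nc1c(C(O)(C(F)(F)F)C(F)(F)F)ccc2ccccc12`, in an assay on LtK cells with ATP-sensitive inward rectifier potassium channel 11 (Homo sapiens) as the target (a lower number here means that less compound is needed, a higher number that more compound is needed for the effect), gives 6630 nM.
Compound 2, `O=C(Nc1c(C(O)(C(F)(F)F)C(F)(F)F)ccc2ccccc12)c1ccccc1`, gives 44 nM.
Compound 3, `Cc1ccccc1C(=O)Nc1c(C(O)(C(F)(F)F)C(F)(F)F)ccc2ccccc12`, gives 5550 nM.

Compound 3 stands second highest of these three numbers. Its nearest neighbour is compound 1, where a 1.2-fold lower number from compound 1 to compound 3 (0.08 log units; within the scatter), so the two cannot be told apart. Its furthest is compound 2, where a 130-fold higher number from compound 2 to compound 3 (2.10 log units; beyond the scatter), a large step.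

Compound 4, `O=C(Nc1c(C(O)(C(F)(F)F)C(F)(F)F)ccc2ccccc12)c1ccc(Cl)cc1`, differs from compound 3 by 4-chlorophenyl in place of 2-methylphenyl on a carbonyl carbon. Among the measured compounds shown here, two measured steps bear on this. First, a 150-fold lower number from compound 1 to compound 2 (2.18 log units; beyond the scatter), showing that an unsubstituted phenyl on the carbonyl carbon gives a far lower number than isopropyl. Second, a 130-fold higher number from compound 2 to compound 3 (2.10 log units; beyond the scatter), showing that a methyl on that ring undoes nearly all of that gain. No measured compound carries a chlorine on the ring, so whether it behaves like the hydrogen of compound 2 or like the methyl of compound 3 is not shown. The expectation is that removing the methyl brings the number down, a 22-fold lower number from compound 3 to compound 4 (1.35 log units; beyond the scatter), though with wide uncertainty. Compound 4 is therefore estimated at 250 nM, between 30 nM and 3000 nM.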

Compound 4, half-maximal effective concentration: 570 nM
Compound 4: middle estimate off by 2.3-fold (0.36 log units), on the low side; the range from low to high includes it.
By their numbers in this assay, from the lowest: compound 2; then compound 4; then compounds 3 and 1 (each within the scatter of the next).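

A substituent on the phenyl ring need not cancel the gain of compound 2 almost entirely: with chlorine in the ring's substituent place, there is a 13-fold higher number from compound 2 to compound 4 (1.11 log units; beyond the scatter), a real loss that still stops well short of the level reached with 2-methylphenyl. In this assay, swapping 2-methylphenyl for 4-chlorophenyl gives a 9.7-fold lower number from compound 3 to compound 4 (0.99 log units; beyond the scatter), and 4-chlorophenyl also keeps a clear advantage over isopropyl, with a 12-fold lower number from compound 1 to compound 4 (1.07 log units; beyond the scatter), so this carbonyl substituent is sensitive to what the ring carries and not merely to the presence of a ring. No measurement shown here explains these differences.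

Compound 3 and compound 4 differ in both the group and its place on the ring, so the contribution of each remains unresolved. As far as these compounds go, how an amine or a carboxylic acid on the phenyl ring, or a longer chain in place of isopropyl, would behave also remains open.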